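Carbamate aryl swap: from 2-methylphenyl to 4-methoxyphenyl

The compounds below may be only part of what the source reports. "The series", "measured", "known", "first", "only" and "open" are said of these compounds alone.

Compound 1 `Cc1c(Cl)cccc1C(=O)OC(CCN(C)C)c1ccc(Cl)cc1` gives 1120 nM in an assay on NIH3T3 cells with Urotensin-2 receptor (Homo sapiens) as the target; a higher number here means that more compound is needed for the effect, a lower number that less compound is needed.
Compound 2 `Cc1ccc(C)c(C(=O)OC(CCN(C)C)c2ccc(Cl)cc2)c1` gives 1860 nM in this assay.
Compound 3 `Cc1ccccc1NC(=O)OC(CCN(C)C)c1ccc(Cl)cc1` gives 3890 nM in this assay.

Compound 3 carries the highest number of the three, so it needs the most compound: a 2.1-fold higher number from compound 2 to compound 3 (0.32 log units; beyond the scatter) and a 3.5-fold higher number from compound 1 to compound 3 (0.54 log units; beyond the scatter) both lie beyond the scatter. Compound 4 `COc1ccc(NC(=O)OC(CCN(C)C)c2ccc(Cl)cc2)cc1` is built from compound 3 by one change, (4-methoxyphenyl in place of 2-methylphenyl on an amide-type nitrogen). Within the data shown here, no measured step touches the aryl group on the amide-type nitrogen. Among the measured compounds shown here, the only step that swaps one aryl group for another, a 1.7-fold higher number from compound 1 to compound 2 (0.22 log units; within the scatter), sits on a carbonyl carbon and stays within the scatter, while the other two steps exchange an ester-type aryl group for an amino-linked one and are therefore a different kind of change. On that basis the expected step of a 1.0-fold higher number from compound 3 to compound 4 (0.01 log units; within the scatter) is none beyond the scatter, with wide uncertainty. Compound 4 is estimated at 4000 nM in this assay, with a plausible range from 1300 nM to 12000 nM.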

Compound 4, half-maximal effective concentration: 1660 nM
Compound 4: middle estimate off by 2.4-fold (0.38 log units), on the high side, within the range that was stated.
By their numbers in this assay, from the lowest: compounds 1, 4 and 2 (each within the scatter of the next); then compound 3.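

The aryl group on the amide-type nitrogen affects the number in this assay: putting 4-methoxyphenyl in place of 2-methylphenyl gives a 2.3-fold lower number from compound 3 to compound 4 (0.37 log units; beyond the scatter), a modest step but one that clears the scatter. Among these compounds, the earlier swap of one aryl group for another, on a carbonyl carbon, stayed within the scatter, so this is the first aryl exchange to produce a readable change. No measurement available here bears on why the number moves.

On these data alone, whether the shift follows the methoxy group itself or its place on the ring stays open, and 2-methoxyphenyl and 4-methylphenyl on this nitrogen would separate the two. Also open, as far as these compounds go, is how the number responds to other groups here, such as plain phenyl, 4-chlorophenyl or 4-aminophenyl.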